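The source may hold more compounds than are shown below. What is called first, only, known or untested is meant among the compounds shown, and "the series" means these compounds.

Values so far in a functional assay on MCF7 cells (Homo sapiens) for cytotoxicity, read by CellTiter-Glo, with a stated time of 5 days; on this read-out higher numbers stand for weaker inhibition and lower numbers for stronger inhibition

- compound 1 `CC/C(=C(/c1ccc(/C=C/C(=O)O)cc1)c1ccc2[nH]ncc2c1)c1ccccc1` gives 6 nM
- compound 2 `CC/C(=C(/c1ccc(/C=C/C(=O)O)cc1)c1ccc2[nH]ncc2c1)c1ccccc1Cl` gives 2 nM
- compound 3 `CC/C(=C(/c1ccc(/C=C/C(=O)O)cc1)c1ccc2[nH]ncc2c1)c1cccc(Cl)c1` gives 12 nM

Compound 3 at 12 nM sits at the weak end of this set, level within the scatter with compound 1 and clearly apart from compound 2. The next structure, compound 4 `CC/C(=C(/c1ccc(/C=C/C(=O)O)cc1)c1ccc2[nH]ncc2c1)c1ccc(Cl)cc1`, carries 4-chlorophenyl in place of 3-chlorophenyl on a double-bonded chain carbon bound to a double-bonded chain carbon and a saturated chain carbon and nothing else changes. Adding chloro gave a 3.0-fold lower number from compound 1 to compound 2 (0.48 log units; beyond the scatter) and also a 2.0-fold higher number from compound 1 to compound 3 (0.30 log units; within the scatter) while changing its place gave a 6.0-fold higher number from compound 2 to compound 3 (0.78 log units; beyond the scatter) and so placement can matter. No measurement covers 4-chlorophenyl yet, so only a modest shift is expected, towards compound 1 at 6 nM rather than beyond it. The expected step is a 2.0-fold lower number from compound 3 to compound 4 (0.30 log units; within the scatter) in this assay by this estimate. For compound 4 the estimated value is 6 nM with an expected range from 2 nM to 18 nM in all.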

Compound 4, half-maximal inhibitory concentration: 15 nM
For compound 4 the middle estimate is 2.5-fold (0.40 log units) below the measured one; the range from low to high includes it.
By their numbers in this assay, from the lowest: compound 2; then compounds 1, 3 and 4 (each within the scatter of the next, the first and the last beyond it).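

In this assay, 4-chlorophenyl and 3-chlorophenyl cannot be told apart at this position (a 1.3-fold higher number from compound 3 to compound 4 (0.10 log units; within the scatter)). Yet 4-chlorophenyl, unlike 3-chlorophenyl, falls clearly on the weaker side of the chlorine-free parent (a 2.5-fold higher number from compound 1 to compound 4 (0.40 log units; beyond the scatter)), and it remains well apart from 2-chlorophenyl (a 7.5-fold higher number from compound 2 to compound 4 (0.88 log units; beyond the scatter)), so 2-chlorophenyl is the only chlorine placement here to give a lower number than the parent. No measurement shown explains this difference. Going by these compounds, whether a methyl or a methoxy group would show the same dependence on placement at these ring positions remains open.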